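Swapping the aryl group from compound 2 to compound 3

The source may hold more compounds than are shown below. What is called first, only, known or untested is meant among the compounds shown, and "the series" means these compounds.

Measured in a functional assay on HOS-TE85 cells (Homo sapiens) for inhibition, read by CCK-8 assay, with a stated time of 72 h (on this read-out lower numbers stand for stronger inhibition and higher numbers for weaker inhibition), so far:
compound 1 `COc1ccc(F)cc1N1C(=O)CSC1c1cccc(C(=O)NCCCCc2ccccc2)c1` gives 8.8 nM
compound 2 `C#Cc1cccc(N2C(=O)CSC2c2cccc(C(=O)NCCCCc3ccccc3)c2)c1` gives 149 nM

Within the data shown here, compound 2 holds the higher of the two numbers, and compound 1 is its only neighbour. Among the measured compounds shown here, compound 3 `COc1ccc(N2C(=O)CSC2c2cccc(C(=O)NCCCCc3ccccc3)c2)c(OC)c1` keeps the shared core and the amide side chain, with 2,4-dimethoxyphenyl in place of 3-ethynylphenyl on an amide-type nitrogen in a ring as the one change. For the measured compounds named here, the only measured step that bears on it is a 17-fold higher number from compound 1 to compound 2 (1.23 log units; beyond the scatter), a large step at the same place. Going by the values given here, compound 3 carries methoxy as compound 1 does but has no fluoro, and no measured compound has the 2,4-dimethoxyphenyl group, so only part of that step is expected to return in this assay, towards a lower number. The expected size is a 5.0-fold lower number from compound 2 to compound 3 (0.70 log units; beyond the scatter), an estimate resting on a single pair. For compound 3 the estimated value is 30 nM, with an expected range from 8 nM to 120 nM on repeated measurement.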

Compound 3, half-maximal inhibitory concentration: 90.4 nM
Beside the measured number, compound 3's estimate is 3.0-fold (0.48 log units) below it; the range from low to high includes it.
By their numbers in this assay, from the lowest: compound 1; then compounds 3 and 2 (each within the scatter of the next).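

In this assay, 2,4-dimethoxyphenyl on the amide-type nitrogen does not separate from 3-ethynylphenyl, with a 1.6-fold lower number from compound 2 to compound 3 (0.22 log units; within the scatter) as the reading at this position. Against 5-fluoro-2-methoxyphenyl the same group shows a 10-fold higher number from compound 1 to compound 3 (1.01 log units; beyond the scatter) and so does not hold the low number of compound 1, although compound 3 also carries methoxy; at this position, a methoxy group alone does not give that number. Nothing in hand accounts for this gap between the aryl groups.

As far as these compounds go, compound 1 and compound 3 differ in both the fluoro group and the second methoxy group, so the share of each in the gap remains open. Also open, from the compounds shown here alone, is how a plain phenyl ring, a pyridine ring or a chloro group in place of fluoro would read at this position.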